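Working notes: the step from compound 2 to compound 3

The source may hold more compounds than are shown below. What is called first, only, known or untested is meant among the compounds shown, and "the series" means these compounds.

compound 1 `C=C1C(=O)O[C@H]2[C@H]1CC/C(COC(=O)N1CCC(F)(F)CC1)=C\CC[C@@]1(C)O[C@@H]21`: 1380 nM
compound 2 `C=C1C(=O)O[C@H]2[C@H]1CC/C(COC(=O)NCCN1CCCC1)=C\CC[C@@]1(C)O[C@@H]21`: 10200 nM

Going by the values given here, in a functional assay on SR cells (Homo sapiens) for inhibition (a lower number here means a stronger inhibitor of growth, a higher number a weaker inhibitor of growth), compound 2 has the higher of the two numbers, 10200 nM, and its only neighbour is compound 1 at 1380 nM. Compound 3 `C=C1C(=O)O[C@H]2[C@H]1CC/C(COC(=O)Nc1n[nH]c(SC)n1)=C\CC[C@@]1(C)O[C@@H]21` is the next to be read. The change is 5-(methylsulfanyl)-1H-1,2,4-triazol-3-yl in place of 2-(pyrrolidin-1-yl)ethyl on an amide-type nitrogen. Among the compounds with values here, one measured step bears on it, a 7.4-fold higher number from compound 1 to compound 2 (0.87 log units; beyond the scatter), which brought in the group now leaving. Within the data shown here, no measured compound carries the entering group, so the direction is only a tentative expectation: a step toward a lower number, of similar or smaller size than that one. The expected step is a 4.1-fold lower number from compound 2 to compound 3 (0.61 log units; beyond the scatter). Compound 3 is estimated at 2500 nM, with an expected range of 700 nM to 9000 nM.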

Compound 3, concentration for 50% growth inhibition: 2360 nM
The estimate for compound 3 lay 1.1-fold (0.03 log units) above the measured number; the measured number falls inside the stated range.
By their numbers in this assay, from the lowest: compounds 1 and 3 (each within the scatter of the next); then compound 2.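

In this assay the 5-(methylsulfanyl)-1H-1,2,4-triazol-3-yl group on the amide-type nitrogen gives a 4.3-fold lower number from compound 2 to compound 3 (0.64 log units; beyond the scatter) with the same heavy-atom count as the group it replaces, so heavy-atom count alone does not set the number at this position. Compound 2 and compound 3 both keep the amide hydrogen, while the comparison with the 4,4-difluoropiperidin-1-yl group shows a 1.7-fold higher number from compound 1 to compound 3 (0.23 log units; within the scatter) and so the high number of compound 2 does not go with that hydrogen as such. No available evidence explains the difference between the two groups.

As far as these compounds go, whether the number follows the aromatic ring, the methylsulfanyl group or the loss of the pyrrolidine ring stays open. A plain phenyl on the same nitrogen, or a 2-(dimethylamino)ethyl chain, would help separate these readings.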